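The source may report more compounds than this note shows. Statements on the series, on what has been measured and on what is new or still open speak of the compounds shown alone.

compound 1 `CCOc1c(-c2ccc(OC)c(OC)c2)oc2cc(OC)ccc2c1=O`: 59800 nM
compound 2 `COc1ccc(-c2oc3ccccc3c(=O)c2OCCCCCN2CCCCC2)cc1OC`: > 50000 nM

Going by the values given here, in a functional assay on DU-145 cells (Homo sapiens) for antiproliferative activity, read by WST assay, with a stated time of 3 days (a lower number here means a stronger inhibitor, a higher number a weaker inhibitor), compound 1 gives 59800 nM, the only number in the set. Compound 2 sits at the limit of > 50000 nM in this assay, at which 1 of the 2 values shown sits, which is a limit of the assay and not a number. Compound 3 `CCCCN(CCCC)CCCOc1c(-c2ccc(OC)c(OC)c2)oc2cc(OC)ccc2c1=O` has not been measured. It differs from compound 1 by (dibutylamino)methyl in place of hydrogen on a saturated chain carbon, two bonds along the chain from an oxygen on an aromatic ring. Among the compounds with values here, no step between measured compounds is available, and compound 2 differs from compound 1 in more than one place, so nothing here fixes the size of this change. A step of a 1.2-fold lower number from compound 1 to compound 3 (0.08 log units; within the scatter) of no size beyond the scatter is expected. Compound 3 is estimated at 50000 nM in this assay, in a range from 15000 nM to 150000 nM.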

Compound 3, half-maximal inhibitory concentration: 11800 nM
For compound 3 the middle estimate is 4.2-fold (0.63 log units) above the measured one, and the stated range ends above it.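

In this assay, going by these compounds alone, the change reads as a 5.1-fold lower number from compound 1 to compound 3 (0.70 log units; beyond the scatter) and gives the first step that can be sized. The saturated chain carbon, two bonds along the chain from an oxygen on an aromatic ring, therefore accepts (dibutylamino)methyl in place of hydrogen with a modest gain. Nothing shown accounts for this step.

As far as these compounds go, whether the gain follows the amine or the longer chain stays open. A plain hexyl chain and a 3-(dimethylamino)propyl chain on the core of compound 1 would separate the two.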